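3-Aminopropyl to allyl on the sulfur chain

A few compounds are considered here, and "the series" means these few. Any claim that something is new, unique, unknown or untested is made for them only; others in the source may bear on it.

Among the compounds with values here, in a functional assay on HT cells (Homo sapiens) for antiproliferative activity, read by fluorescence, with a stated time of 72 h (on this read-out lower numbers stand for stronger inhibition of growth and higher numbers for weaker inhibition of growth), compound 1 `CC(C)c1n[nH]c2c(NCc3ccc(-c4ccccn4)cc3)nc(SCCNC(N)=O)nc12` gives 240 nM and compound 2 `CC(C)c1n[nH]c2c(NCc3ccc(-c4ccccn4)cc3)nc(SCCCN)nc12` gives 120 nM as its reading, so compound 2 stands level with the only other measured compound, within the scatter. Next in the series is compound 3 `C=CCSc1nc(NCc2ccc(-c3ccccn3)cc2)c2[nH]nc(C(C)C)c2n1`, which carries the change vinyl in place of 2-aminoethyl on a saturated chain carbon bound to a sulfur on the sulfur chain. In words, vinyl takes the place of 2-aminoethyl on a saturated chain carbon bound to a sulfur. Cut one bond further out, the same difference reads 3-aminopropyl to allyl.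

Within the data shown here, the one measured step on this chain is a 2.0-fold lower number from compound 1 to compound 2 (0.30 log units; within the scatter) with aminomethyl in place of ureido, and it gives no ground to expect a large move in this assay here. Among the measured compounds shown here, no measured compound ends in allyl, so that step is only weak guidance and the expected range stays wide. The expectation is a 1.5-fold higher number from compound 2 to compound 3 (0.18 log units; within the scatter) with no move beyond the scatter. The estimated value for compound 3 is 180 nM with an expected range of 70 nM to 450 nM in this read-out.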

Compound 3, concentration for 50% growth inhibition: 1010 nM
Compound 3: the middle estimate sits 5.6-fold (0.75 log units) below what was measured, and the stated range ends below it.
By their numbers in this assay, from the lowest: compounds 2 and 1 (each within the scatter of the next); then compound 3.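

In this assay, the group on the sulfur chain can move the number beyond the scatter (an 8.4-fold higher number from compound 2 to compound 3 (0.93 log units; beyond the scatter)), which the earlier step between the ureido and amine chain ends did not show (a 2.0-fold lower number from compound 1 to compound 2 (0.30 log units; within the scatter)). Compound 3 also stands apart from the ureido compound (a 4.2-fold higher number from compound 1 to compound 3 (0.62 log units; beyond the scatter)), so among the three compounds shown, both chains that end in a nitrogen-bearing group, in compound 1 and compound 2, give lower numbers than the allyl chain, and none of the three goes against this. Nothing available on this series accounts for the loss of growth inhibition with the allyl group.

The change from 3-aminopropyl to allyl removes the terminal amine and brings in a double bond together, so the compounds shown leave open which of the two matters; a saturated propyl group on the sulfur would separate them. Also open, from the compounds shown here alone, is whether the chain end needs nitrogen at all, a question that a hydroxyl group or a carboxylic acid at the chain end could address, and how a longer chain such as 4-aminobutyl would read.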